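The compounds below may be only part of what the source reports. "The series", "measured", "known", "first", "only" and "open" are said of these compounds alone.

In a physicochemical assay for solubility, in phosphate buffer, with a stated time of 18 h (on this read-out lower numbers stand for lower solubility and higher numbers for higher solubility), compound 1 (`Cc1nc(C(C)(C)C)nc2nc(N)c(C#N)c(N)c12`) gives 37000 nM. Compound 2 (`CC(C)(C)c1nc(C2CCCC2)c2c(N)c(C#N)c(N)nc2n1`) gives < 1000 nM, which is a limit of the assay. Compound 3 (`CC(C)(C)c1nc(-c2cccs2)c2c(N)c(C#N)c(N)nc2n1`) gives 56000 nM, and it stands with compound 1 at the top of the numbers shown, the two lying within the scatter: a 1.5-fold higher number from compound 1 to compound 3 (0.18 log units; within the scatter). Compound 4 (`CC(C)(C)c1nc(-c2ccc(C(=O)O)s2)c2c(N)c(C#N)c(N)nc2n1`) differs from compound 3 by carboxy in place of hydrogen on an aromatic carbon. Among the compounds with values here, no measured step adds this group. The nearest steps replace the whole group that carries it, and they range from a 1.5-fold higher number from compound 1 to compound 3 (0.18 log units; within the scatter) to the large at least 56-fold higher number from compound 2 to compound 3 (1.74 log units; beyond the scatter). In this assay, the expected change is a 2.5-fold higher number from compound 3 to compound 4 (0.40 log units; beyond the scatter), a moderate step to a higher number. For compound 4 the estimated value is 140000 nM, with an expected range from 45000 nM to 400000 nM.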

Compound 4, solubility: > 1000000 nM
Compound 4 ended at the assay's limit; the forecaster's own chance of this, stated with the estimate: 25%; middle value at least 7.1-fold (0.85 log units) from the limit.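

In this assay compound 4 gives > 1000000 nM, which is a limit of the assay and not a number. The earlier steps shown here only replaced the whole group at this position, whereas adding carboxy to the thiophen-2-yl group itself gives an at least 17-fold higher number from compound 3 to compound 4 (1.25 log units; beyond the scatter), so a change on this ring alone produces a large step. The 5-carboxythiophen-2-yl group also stands well clear of the two alkyl groups, with an at least 27-fold higher number from compound 1 to compound 4 (1.43 log units; beyond the scatter) and an at least 1000-fold higher number from compound 2 to compound 4 (3.00 log units; beyond the scatter).

From the compounds shown here alone, how far the true value of compound 4 lies beyond its limit remains open. Going by these compounds, whether a methyl ester or a primary amide in place of carboxy would give a step of similar size also remains open.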